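The source may hold more compounds than are shown below. What is called first, only, known or untested is meant among the compounds shown, and "the series" means these compounds.

Compound 1 `CC1CCN(c2nc(Cl)nc3c2ncn3Cc2ccc(/C=C/C(=O)Nc3ccccc3N)cc2)CC1` is a chlorinated fused core carrying a 4-methylpiperidin-1-yl group and a cinnamamide bearing an aminophenyl amide. In a functional assay on NCI-H460 cells (Homo sapiens) for antiproliferative activity, read by CCK-8 assay, with a stated time of 72 h, tested at 2 uM (a higher number here means a stronger effect of the compound at the concentration tested, a lower number a weaker effect), compound 1 gives 8.24%, the lowest of the two numbers at hand. The other measured compound, compound 2 `CC(C)n1cnc2c(NCc3ccc(C(=O)Nc4ccccc4N)cc3)nc(Cl)nc21`, differs from it in several places at once; in this assay compound 2 gives 54.2%, a gap beyond the scatter. Compound 3 `Nc1ccccc1NC(=O)/C=C/c1ccc(Cn2cnc3c(NC4CCCCC4)nc(Cl)nc32)cc1` has the same atoms as compound 1, joined differently: cyclohexylamino in place of 4-methylpiperidin-1-yl on an aromatic carbon. Going by the values given here, no pair of measured compounds differing in this single place exists, so the size of the step is open. Compound 3 is nonetheless expected to sit higher than compound 1, because compound 2 gives 54.2% with a related amino substituent on the same core. The step of a number 16.8 percentage points higher from compound 1 to compound 3 (beyond the scatter) is expected to be modest and probably beyond the scatter. For compound 3 the estimate is 25%, within 5% to 55%.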

Compound 3, a percentage reported as inhibition, at one concentration (the size of the read-out at that concentration, not a potency): 8.09%
The estimate for compound 3 lay 16.9 percentage points above the measured number; measured number inside the range.
By their numbers in this assay, from the lowest: compounds 3 and 1 (each within the scatter of the next); then compound 2.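

In this assay, going by these compounds alone, the first single-place step at this position is a number 0.2 percentage points lower from compound 1 to compound 3 (within the scatter), with cyclohexylamino in place of 4-methylpiperidin-1-yl on the aromatic carbon next to the ring nitrogen. The entering group has 1 hydrogen-bond donor and the leaving group has 0, yet at this one concentration the two compounds cannot be told apart, so this exchange between two six-membered non-aromatic rings of equal heavy-atom count does not separate them. No measurement at hand accounts for this result.

The compounds shown leave open whether a different group on this aromatic carbon, such as morpholin-4-yl or a short dimethylamino group, would give a read-out beyond the scatter from compound 1. Also open, from the compounds shown here alone, is which of the several places where compound 2 differs from compound 1 goes with its separate number.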